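Swapping 3-fluorobenzyl for cyclohexyl: Vero cell cytotoxicity

The compounds below may be only part of what the source reports. "The series", "measured", "known", "first", "only" and "open" are said of these compounds alone.

Compound 1 `O=c1nc(NCc2cccc(F)c2)oc2c([N+](=O)[O-])cc(C(F)(F)F)cc12` gives > 64 ug/mL in an ADME assay on Vero cells (Chlorocebus sabaeus) for cytotoxicity, read by MTT assay, with a stated time of 48 h; a lower number here means a stronger inhibitor, a higher number a weaker inhibitor.
Compound 2 `O=c1cc(NCc2ccc3c(c2)OCCO3)sc2c([N+](=O)[O-])cc(C(F)(F)F)cc12` gives > 64 ug/mL in this assay.
Compound 3 `O=c1cc(NCc2cccc(F)c2)sc2c([N+](=O)[O-])cc(C(F)(F)F)cc12` gives > 64 ug/mL in this assay.

Every one of these three values is a limit of the assay rather than a measured number, and all sit at the limit of > 64 ug/mL in this assay, at which 3 of the 3 values shown sit. Compound 1 therefore stands no higher or lower than the others; the data show only that none of the three reaches the top concentration. Among the measured compounds shown here, the one pairwise comparison available, a step that the two limits leave unreadable from compound 2 to compound 3, cannot be sized for the same reason.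

Compound 4 `O=c1nc(NC2CCCCC2)oc2c([N+](=O)[O-])cc(C(F)(F)F)cc12` differs from compound 1 by cyclohexyl in place of 3-fluorobenzyl on a nitrogen on an aromatic ring. For the measured compounds named here, no measured step touches this change, and the only evidence to lean on is that compound 1, with the 3-fluorobenzyl in place, gives > 64 ug/mL. With nothing pointing either way, compound 4 is expected to behave like its parent, an estimated step of a number no higher from compound 1 to compound 4 (the limit leaves the size open) that stays within the scatter. Compound 4 is thus estimated at 64 ug/mL, between 32 ug/mL and 128 ug/mL, most likely reported again only as a limit.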

Compound 4, half-maximal inhibitory concentration: 5.39 ug/mL
Compound 4: the middle estimate sits 12-fold (1.07 log units) above what was measured; measured number below the stated range.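

In this assay, cyclohexyl in place of 3-fluorobenzyl on the nitrogen gives an at least 11-fold lower number from compound 1 to compound 4 (1.07 log units; beyond the scatter), so the group at this place can move the read-out by a large margin. Compound 4 is the only compound shown with a measured number rather than a limit: the limit of > 64 ug/mL in this assay, at which 3 of the 4 values shown sit. The change removes an aromatic ring, the fluorine and the chain carbon in a single step and puts a non-aromatic ring in their stead, so the step cannot be assigned to any one of these.

Which part of the swap carries the step stays open, and an unsubstituted benzyl or a cyclohexylmethyl on the same nitrogen would bear on that question. On these data alone, whether cyclohexyl acts in the same way on the core of compound 3 also stays open.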